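The source may hold more compounds than are shown below. What is called first, only, known or untested is meant among the compounds shown, and "the series" means these compounds.

Three compounds have been measured in a functional assay on renal cells (Homo sapiens) for antiproliferative activity; on this read-out higher numbers stand for weaker inhibition of growth and lower numbers for stronger inhibition of growth:

- compound 1, `Cc1sc2nc(-c3ccncc3)c(/C=N/NC(=N)N)n2c1C`, gives 39800 nM
- compound 2, `Cc1cn2c(/C=N/NC(=N)N)c(-c3cccnc3)nc2s1`, gives 9550 nM
- compound 3, `N=C(N)N/N=C/c1c(-c2cccnc2)nc2sc(Cl)cn12`, gives 18200 nM

Compound 2 has the lowest number of the three. Going by the values given here, the nearest is compound 3: a 1.9-fold higher number from compound 2 to compound 3 (0.28 log units; within the scatter), the only single-place step in the set, with chloro in place of methyl on an aromatic carbon. Compound 1 lies furthest from compound 2, beyond the scatter, but the two differ in more than one place, so no single step can be read from that gap.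

Compound 4, `Cc1cn2c(/C=N/NC(=N)N)c(-c3ccccn3)nc2s1`, awaits measurement. It differs from compound 2 in one place: pyridin-2-yl in place of pyridin-3-yl on an aromatic carbon. Among the compounds with values here, no measured step moves the pyridinyl group in this way; the one step that exists, from compound 2 to compound 3, concerns another part of the shared core and stays within the scatter. Without a guide for this change, the expectation rests on compound 2 alone, and the expected step is a 1.3-fold higher number from compound 2 to compound 4 (0.10 log units; within the scatter). Compound 4 is therefore estimated at 12000 nM, within a range from 4000 nM to 40000 nM.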

Compound 4, concentration for 50% growth inhibition: 7940 nM
Estimate against measurement, compound 4: 1.5-fold (0.18 log units) above; the range from low to high includes it.
By their numbers in this assay, from the lowest: compounds 4, 2 and 3 (each within the scatter of the next, the first and the last beyond it); then compound 1.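

In this assay, pyridin-2-yl in place of pyridin-3-yl gives a 1.2-fold lower number from compound 2 to compound 4 (0.08 log units; within the scatter), so the two groups cannot be told apart on this read-out. Going by these compounds alone, the earlier single-place step concerned another part of the shared core, and this is the first step that reads the group on this aromatic carbon of the five-membered ring: with the same atoms and the same counted donors and acceptors, shifting the nitrogen within the pyridine ring leaves the number within the scatter. Nothing available explains why this step is so small.

Still open, as far as these compounds go, is whether a plain phenyl ring, with no ring nitrogen at all, would also stay within the scatter on this carbon. From the compounds shown here alone, it is also open whether an amine or a carboxylic acid on that ring would move the number beyond it.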